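A few compounds are considered here, and "the series" means these few. Any claim that something is new, unique, unknown or untested is made for them only; others in the source may bear on it.

Measured compounds:
- compound 1, `CC(C)CN(CC(C)C)S(=O)(=O)c1ccc(NC(=O)C(C)(O)C(F)(F)F)cc1`: > 30000 nM
- compound 2, `CC(O)(C(=O)Nc1ccc(S(=O)(=O)N2CCOCC2)cc1)C(F)(F)F`: 5850 nM
- compound 3, `CC(O)(C(=O)Nc1ccc(S(=O)(=O)N2CCCCC2)cc1)C(F)(F)F`: 9250 nM

The shared core carries a sulfonyl sulfur on the aromatic carbon, and the amine on that sulfur is the only thing that varies. In an assay on a protein complex (Cavia porcellus) with sulfonylurea receptors; K-ATP channels (Homo sapiens) as the target (on this read-out higher numbers stand for weaker inhibition and lower numbers for stronger inhibition), compound 1 reaches only a limit of the assay, (the limit of > 30000 nM in this assay, at which 1 of the 3 values shown sits), not a number. Compound 2 and compound 3 both give numbers; between them stands a 1.6-fold higher number from compound 2 to compound 3 (0.20 log units; within the scatter), so no order can be read from the two. Against compound 1 the steps of an at least 5.1-fold lower number from compound 1 to compound 2 (0.70 log units; beyond the scatter) and an at least 3.2-fold lower number from compound 1 to compound 3 (0.51 log units; beyond the scatter) are both beyond the scatter.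

Compound 4, `CC(O)(C(=O)Nc1ccc(S(=O)(=O)N2CCSCC2)cc1)C(F)(F)F`, differs from compound 3 by thiomorpholin-4-yl in place of piperidin-1-yl on a sulfonyl sulfur. Among the compounds with values here, the nearest measured step is the one that also exchanges a ring carbon of piperidin-1-yl for a hetero atom, a 1.6-fold higher number from compound 2 to compound 3 (0.20 log units; within the scatter), which lay within the scatter. Within the data shown here, no other measured step touches a thiomorpholin-4-yl. On this basis the expected step in this assay is a 1.2-fold lower number from compound 3 to compound 4 (0.09 log units; within the scatter), that is, none beyond the scatter. Compound 4 is therefore estimated at 7500 nM, expected between 3000 nM and 20000 nM.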

Compound 4, half-maximal inhibitory concentration: 4580 nM
Beside the measured number, compound 4's estimate is 1.6-fold (0.21 log units) above it; the measured number falls inside the stated range.
By their numbers in this assay, from the lowest: compounds 4, 2 and 3 (each within the scatter of the next, the first and the last beyond it). At a limit, above all of these: compound 1.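

In this assay, thiomorpholin-4-yl in place of piperidin-1-yl on the sulfonyl sulfur gives a 2.0-fold lower number from compound 3 to compound 4 (0.31 log units; beyond the scatter), a modest step and the first between two ring amines at this position that is printed as beyond the scatter. Thiomorpholin-4-yl in place of morpholin-4-yl gives a 1.3-fold lower number from compound 2 to compound 4 (0.11 log units; within the scatter), so these two rings cannot be ordered, and morpholin-4-yl also remains unresolved from piperidin-1-yl. Compound 1 remains a limit and not a number, so an at least 6.5-fold lower number from compound 1 to compound 4 (0.81 log units; beyond the scatter) gives only a bound: the limit of > 30000 nM in this assay, at which 1 of the 4 values shown sits.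

Within the data shown here, whether the ring sulfur itself accounts for the step from piperidin-1-yl remains open, as the series holds only one sulfur-containing ring. Also open, on these data alone, is what a piperazin-1-yl or pyrrolidin-1-yl ring on the sulfonyl sulfur would give in this assay.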